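The source may hold more compounds than are shown below. What is called first, only, known or untested is meant among the compounds shown, and "the series" means these compounds.

Compound 1 `COC(=O)C1=C(C)N=C(C)/C(=C(/O)OC)C1c1cccc(N/C(=N/CCNC2CCN(c3ccccc3[N+](=O)[O-])CC2)NC#N)c1` is the starting point of this account. In an assay on SK-N-MC cells for inhibition of Neuropeptide Y receptor type 1 (Homo sapiens) (a lower number here means a stronger inhibitor, a higher number a weaker inhibitor), compound 1 gives 4 nM, level at the digits shown with compound 2 `COC(=O)C1=C(C)N=C(C)/C(=C(/O)OC)C1c1cccc(N/C(=N/CCNC2CCN(c3ccccc3OC)CC2)NC#N)c1`, which in this assay gives 4 nM; together they carry the lowest two of the three numbers at hand, and compound 3 `COC(=O)C1=C(C)N=C(C)/C(=C(/O)OC)C1c1cccc(N/C(=N/CCNC2CCN(c3ccccc3O)CC2)NC#N)c1`, which in this assay gives 5 nM, lies within the scatter of both.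

The step under consideration leads from compound 1 to compound 4 `COC(=O)C1=C(C)N=C(C)/C(=C(/O)OC)C1c1cccc(N/C(=N/CCNC2CCN(c3ccccc3SC)CC2)NC#N)c1` and consists of methylsulfanyl in place of nitro on an aromatic carbon. Two measured steps replace the same nitro group at the same aromatic carbon: no change at the digits printed from compound 1 to compound 2 (within the scatter) and a 1.3-fold higher number from compound 1 to compound 3 (0.10 log units; within the scatter). Neither left the scatter, and the further step between the two resulting compounds, a 1.3-fold higher number from compound 2 to compound 3 (0.10 log units; within the scatter), was equally small. Since every replacement of this nitro group seen so far has left this assay unmoved, compound 4 is expected to behave alike, with an estimated step of no change at the digits printed from compound 1 to compound 4 (within the scatter), no change beyond the scatter in either direction. Compound 4 is therefore estimated at 4 nM, with a range from 2 nM to 9 nM.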

Compound 4, half-maximal inhibitory concentration: 3 nM
Compound 4: the middle estimate sits 1.3-fold (0.12 log units) above what was measured; the range from low to high includes it.
By their numbers in this assay, from the lowest: compounds 4, 1, 2 and 3 (each within the scatter of the next).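

Methylsulfanyl, the only sulfur-bearing group among these compounds, extends the picture at this aromatic carbon in this assay, with a 1.3-fold lower number from compound 1 to compound 4 (0.12 log units; within the scatter). Set against the two other replacements, it gives a 1.3-fold lower number from compound 2 to compound 4 (0.12 log units; within the scatter) and a 1.7-fold lower number from compound 3 to compound 4 (0.22 log units; within the scatter), so nitro, methoxy, hydroxy and methylsulfanyl cannot be told apart here, and the widest gap among the four compounds still stays inside the scatter. Nothing available speaks to why these four groups read alike.

The compounds shown leave open whether this flat reading would survive a carboxylic acid, an amine or a longer alkoxy chain on the same aromatic carbon, or plain hydrogen there. They also leave open whether moving any of these groups elsewhere on the same ring would read alike.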